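Thiophene-to-phenyl swap on the shared core

This account rests on a few compounds, and the source may have more. Where it says the series, first, only, none or still open, it means among the compounds named here.

Compound 1 `Cn1cccc1-c1cc(-c2cccs2)[nH]c(=O)c1C#N` gives 22900 nM in a functional assay on IGROV-1 cells (Homo sapiens) for inhibition, read by sulforhodamine B assay, with a stated time of 48 h (a lower number here means a stronger inhibitor of growth, a higher number a weaker inhibitor of growth), and holds the lowest of the two numbers shown; compound 3 `COc1ccc(-c2cc(-c3cccn3C)c(C#N)c(N)n2)cc1OC` sits at 95500 nM in this assay, a gap beyond the scatter. Compound 2 `CC1CCCc2c1[nH]c(=O)c(C#N)c2-c1cccn1C` reports only a limit, > 100000 nM in this assay, which is the limit of > 100000 nM in this assay, at which 1 of the 3 values shown sits.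

Compound 4 `Cn1cccc1-c1cc(-c2ccccc2)[nH]c(=O)c1C#N` differs from compound 1 by phenyl in place of thiophen-2-yl on an aromatic carbon. No measured step of this kind exists among the compounds shown, so the expectation rests on the size of the change alone. The expected step of a 1.3-fold higher number from compound 1 to compound 4 (0.12 log units; within the scatter) is judged to stay within the usual scatter, with no clear direction. Compound 4 is therefore estimated at 30000 nM, with a range from 10000 nM to 90000 nM.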

Compound 4, concentration for 50% growth inhibition: > 100000 nM
Compound 4: only a limit was reported; the forecaster's own chance of this, stated with the estimate: 15%; middle value at least 3.3-fold (0.52 log units) from the limit.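

On the shared core, the aromatic carbon next to the ring nitrogen does not take these two rings alike: phenyl in place of thiophen-2-yl gives an at least 4.3-fold higher number from compound 1 to compound 4 (0.64 log units; beyond the scatter). For the compounds shown here, this is the first measured step, and it ties the growth inhibition of compound 1 to the ring at this position. The value of compound 4 is a limit, not a number, and the step carries that limit: the limit of > 100000 nM in this assay, at which 2 of the 4 values shown sit.

The swap changes ring size and removes the sulfur together, and the compounds shown do not separate the two. As far as these compounds go, whether furan-2-yl or a phenyl bearing an amine would hold the value of compound 1 stays open.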